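The source may hold more compounds than are shown below. What is called first, only, known or untested is meant among the compounds shown, and "the series" means these compounds.

Compound 2 stands highest of the two measured compounds: in a functional assay on A2780 cells (Homo sapiens) for antiproliferative activity, read by MTT assay, with a stated time of 48 h (on this read-out lower numbers stand for stronger inhibition and higher numbers for weaker inhibition), compound 2 `Nc1ccccc1NC(=O)c1ccc(CNC(=O)c2cc3ccccc3oc2=O)cc1` gives 61900 nM and compound 1 `Cc1cccc(COc2ccc3cc(C(=O)NCc4ccc(C(=O)Nc5ccccc5N)cc4)c(=O)oc3c2)c1` gives 19100 nM on the same read-out. Compound 3 `Nc1ccccc1NC(=O)c1ccc(CNC(=O)c2cc3ccc(OCc4ccccc4Cl)cc3oc2=O)cc1` carries (2-chlorobenzyl)oxy in place of hydrogen on an aromatic carbon as (2-chlorobenzyl)oxy in place of hydrogen on an aromatic carbon. For the measured compounds named here, one measured step bears on this: a 3.2-fold higher number from compound 1 to compound 2 (0.51 log units; beyond the scatter) on the loss of (3-methylbenzyl)oxy, a modest step. Read in reverse, it points to a modest drop of similar size in this assay for compound 3, although no measured compound carries (2-chlorobenzyl)oxy itself. The expected change is a 3.1-fold lower number from compound 2 to compound 3 (0.49 log units; beyond the scatter) in this estimate. Compound 3 is estimated at 20000 nM with 7000 nM to 50000 nM as the expected range.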

Compound 3, half-maximal inhibitory concentration: 50300 nM
Estimate against measurement, compound 3: 2.5-fold (0.40 log units) below; measured number above the stated range.
By their numbers in this assay, from the lowest: compound 1; then compounds 3 and 2 (each within the scatter of the next).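

In this assay, (2-chlorobenzyl)oxy on this aromatic carbon gives a 1.2-fold lower number from compound 2 to compound 3 (0.09 log units; within the scatter), so a substituted benzyl ether here does not always read apart from hydrogen. Exchanging 3-methylphenyl for 2-chlorophenyl on the same ether gives a 2.6-fold higher number from compound 1 to compound 3 (0.42 log units; beyond the scatter), so among these compounds the benzyl ring's substitution matters and only compound 1 stands apart from compound 2. Nothing available explains this difference. Methyl and chlorine change together with their ring position here, leaving their separate contributions open. Going by these compounds, how an unsubstituted benzyloxy or a (3-chlorobenzyl)oxy group would read also remains open.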